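The source may hold more compounds than are shown below. What is called first, only, known or untested is meant among the compounds shown, and "the series" means these compounds.

In an ADME assay on Raji cells (Homo sapiens) for cytotoxicity, read by CellTiter-Glo and resazurin assay, with a stated time of 72 h (on this read-out lower numbers stand for an effect already at smaller amounts and higher numbers for an effect only at larger amounts of compound), the measured compounds stand as follows. Compound 1 `CC(C)N(Cc1cccc(OCCCCCC(=O)O)c1)C(=O)c1ccc(-c2cccc(-c3ccccc3)c2)cc1` gives > 26000 nM, which is a limit of the assay. Compound 2 `CC(C)Oc1cccc(-c2ccc(C(=O)N(Cc3cccc(OCCCCCC(=O)O)c3)C(C)C)cc2)c1` gives > 26000 nM, also a limit. Compound 3 `CCOC(=O)CCCCCOc1cccc(CN(C(=O)c2ccc(-c3cccc(-c4ccccc4)c3)cc2)C(C)C)c1` gives > 26000 nM, again a limit and not a number.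

Compound 3 therefore sits at the limit of > 26000 nM in this assay, at which 3 of the 3 values shown sit, as do the two other values shown, so no number places it relative to compound 1 or compound 2. Compound 4 `CCOC(=O)CCCCCOc1cccc(CN(C(=O)c2ccc(-c3cccc(OC(C)C)c3)cc2)C(C)C)c1` is not yet measured. It differs from compound 3 by isopropoxy in place of phenyl on an aromatic carbon. The same structural change has been made once before, as the step that the two limits leave unreadable from compound 1 to compound 2, and compound 3 itself came from compound 1 through a step that the two limits leave unreadable from compound 1 to compound 3; neither step can be read, because both ends of each sit at the limit of this assay. With every measured value at the limit, no direction or size can be drawn from the data, and compound 4 is expected to remain at or near that limit, so that the step that the limit leaves unreadable from compound 3 to compound 4 is estimated to be none beyond the scatter. Compound 4 is accordingly expected to give about 40000 nM, within a range from 12000 nM to 150000 nM, most likely reported again only as a limit.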

Compound 4, half-maximal effective concentration: > 26000 nM
Compound 4: only a limit was reported (the forecaster's own chance of this, stated with the estimate: 90%); the middle value is on the limit's open side.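

Neither the step from compound 3 to compound 4 nor the one from compound 2 to compound 4 can be read, because both ends of each are limits and not numbers: the limit of > 26000 nM in this assay, at which 4 of the 4 values shown sit.

The compounds shown leave open whether isopropoxy in place of phenyl, or ethyl in place of hydrogen, changes the effect on these cells at all.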